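The compounds below may be only part of what the source reports. "The series", "measured", "known", "first", "only" and "open" are said of these compounds alone.

The measured compounds, all tested in an assay on HEK293 cells for antagonist activity at Toll-like receptor 9 (Homo sapiens), read by spectrophotometry; a lower number here means a stronger inhibitor, a higher number a weaker inhibitor:

Compound 1 `Nc1nc(N2CCN(C3CCCC3)CC2)c2ncn(CCCN3CCCC3)c2n1`: compound 1 gives 120 nM
Compound 2 `CN(C)Cc1ccc(CNc2nc(N3CCN(C4CCCC4)CC3)c3ncn(CCCN4CCCC4)c3n2)cc1`: compound 2 gives 7 nM
Compound 3 `Fc1ccc(CNc2nc(N3CCN(C4CCCC4)CC3)c3ncn(CCCN4CCCC4)c3n2)cc1`: compound 3 gives 100 nM

Compound 3 stands second highest of the three numbers; its nearest neighbour is compound 1, from which it is separated only within the scatter (a 1.2-fold lower number from compound 1 to compound 3 (0.08 log units; within the scatter)), while compound 2 lies far from it (a 14-fold higher number from compound 2 to compound 3 (1.15 log units; beyond the scatter)). The step to compound 4 `COc1ccc(CNc2nc(N3CCN(C4CCCC4)CC3)c3ncn(CCCN4CCCC4)c3n2)cc1` is methoxy in place of fluoro on an aromatic carbon, set on an aromatic carbon of a six-membered aromatic ring of carbon only.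

Among the compounds with values here, no measured step exchanges one small group on that ring for another. The two large steps, a 17-fold lower number from compound 1 to compound 2 (1.23 log units; beyond the scatter) and a 14-fold higher number from compound 2 to compound 3 (1.15 log units; beyond the scatter), both involve the (dimethylamino)methyl group, which is absent from compound 3 and from compound 4 alike. Within the data shown here, the one step that stays within the scatter, a 1.2-fold lower number from compound 1 to compound 3 (0.08 log units; within the scatter), shows that fluoro added little over hydrogen. On that basis the expected step in this assay is small, a 1.3-fold lower number from compound 3 to compound 4 (0.10 log units; within the scatter), with no firm direction. Compound 4 is therefore estimated at 80 nM, within a range of 30 nM to 250 nM.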

Compound 4, half-maximal inhibitory concentration: 240 nM
For compound 4 the middle estimate is 3.0-fold (0.48 log units) below the measured one, and the stated range covers the measured number.
By their numbers in this assay, from the lowest: compound 2; then compounds 3, 1 and 4 (each within the scatter of the next, the first and the last beyond it).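

In this assay, within the data shown here, methoxy in place of fluoro is the first exchange of one small group for another on this ring, para to a large group, and the position responds to it (a 2.4-fold higher number from compound 3 to compound 4 (0.38 log units; beyond the scatter)). Yet 4-methoxybenzyl in place of hydrogen on the nitrogen stays within the scatter (a 2.0-fold higher number from compound 1 to compound 4 (0.30 log units; within the scatter)), and the gap to the (dimethylamino)methyl group remains wide (a 34-fold higher number from compound 2 to compound 4 (1.54 log units; beyond the scatter)). No measurement at hand accounts for the difference between fluoro and methoxy.

The compounds shown leave open whether the gain seen with (dimethylamino)methyl needs that particular amine, or whether a primary aminomethyl group or a longer aminoethyl chain at the same place would serve as well. They also leave open how a carboxylic acid or a hydroxyl group there would read in this assay.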